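A few compounds are considered here, and "the series" means these few. Any claim that something is new, unique, unknown or untested is made for them only; others in the source may bear on it.

In a functional assay on Raji cells (Homo sapiens) for cytotoxicity, with a stated time of 72 h (a higher number here means that more compound is needed for the effect, a lower number that less compound is needed), compound 1 `C=C[C@@](C)(/C=C/c1ccc(Nc2ccc(OC)cc2)cc1)CCC=C(C)C` gives > 26000 nM as a limit, not a number. Compound 2 `C=C[C@@](C)(/C=C/c1ccc(Nc2cc(F)cc(F)c2)cc1)CCC=C(C)C` gives > 26000 nM as a limit too. Compound 3 `C=C[C@@](C)(/C=C/c1ccc(Nc2ccc(Cl)c(F)c2)cc1)CCC=C(C)C` also gives > 26000 nM as a limit. Together they stand at the limit of > 26000 nM in this assay, at which 3 of the 3 values shown sit, and cannot be ranked.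

Compound 4 `C=C[C@@](C)(/C=C/c1ccc(-c2cccc(F)c2)cc1)CCC=C(C)C` differs from compound 3 in one place: 3-fluorophenyl in place of (4-chloro-3-fluorophenyl)amino on an aromatic carbon with 3-fluorophenyl in place of (4-chloro-3-fluorophenyl)amino on an aromatic carbon, para to a large group.

The measured steps offer little guidance. They are a step that the two limits leave unreadable from compound 1 to compound 2 then a step that the two limits leave unreadable from compound 1 to compound 3 and finally a step that the two limits leave unreadable from compound 2 to compound 3 and all of them keep the nitrogen, which compound 4 lacks.

Compound 3 offers only > 26000 nM as a starting point, a limit, so no clear shift in this assay can be expected in either direction. The expected change is a number no higher from compound 3 to compound 4 (the limit leaves the size open) and it is a rough estimate. For compound 4 the estimated value is 26000 nM with an expected range from 12000 nM to 50000 nM. Compound 4 may again yield only a limit.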

Compound 4, half-maximal effective concentration: > 26000 nM
Compound 4: a limit, no number; the forecaster's own chance of this, stated with the estimate: 70%; the middle value sits exactly at the limit.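

In this assay compound 4 gives > 26000 nM, a limit and not a number. The steps linking compound 4 to compound 1, compound 2 and compound 3 cannot be read. The compounds shown leave open how these four rank against one another, since all stand at one limit: the limit of > 26000 nM in this assay, at which 4 of the 4 values shown sit.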